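Benzyl ether in place of cyclohexylmethyl ether on a chromone dimer

This account rests on a few compounds, and the source may have more. Where it says the series, first, only, none or still open, it means among the compounds named here.

Measured compounds:
compound 1 `O=c1c(Cc2coc3cccc(OCC4CCCCC4)c3c2=O)coc2ccccc12` gives 4230 nM
compound 2 `COc1ccc2c(=O)c(Cc3coc4cccc(OCC5CCCCC5)c4c3=O)coc2c1` gives 1350 nM

In a functional assay on ACHN cells (Homo sapiens) for antiproliferative activity, read by XTT assay (a higher number here means a weaker inhibitor, a lower number a stronger inhibitor), compound 1 stands highest of the two numbers; the nearest is compound 2, reached by a 3.1-fold lower number from compound 1 to compound 2 (0.50 log units; beyond the scatter). Compound 3 `O=c1c(Cc2coc3cccc(OCc4ccccc4)c3c2=O)coc2ccccc12` differs from compound 1 by phenyl in place of cyclohexyl on a saturated chain carbon bound to an oxygen on an aromatic ring. Going by the values given here, the one measured step concerns a methoxy elsewhere on the shared core and does not bear on this change, so no step beyond the scatter is expected in this assay for compound 3. The estimate for compound 3 is 4000 nM with a range of 1500 nM to 11000 nM, meaning a 1.1-fold lower number from compound 1 to compound 3 (0.02 log units; within the scatter).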

Compound 3, half-maximal inhibitory concentration: 3990 nM
Beside the measured number, compound 3's estimate is 1.0-fold (0.00 log units) above it; measured number inside the range.
By their numbers in this assay, from the lowest: compound 2; then compounds 3 and 1 (each within the scatter of the next).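

In this assay, phenyl in place of cyclohexyl on a saturated chain carbon bound to an oxygen on an aromatic ring gives a 1.1-fold lower number from compound 1 to compound 3 (0.03 log units; within the scatter), so the aromatic and the non-aromatic ring cannot be told apart here. Going by these compounds alone, this is the first reading of this position; the earlier step concerned only a methoxy elsewhere on the shared core. Nothing available explains this result.

Still open, on these data alone, is whether an amine or a carboxylic acid on the phenyl, or a longer chain in place of benzyl, would move the number. Also open, as far as these compounds go, is whether methoxy on the shared core of compound 3 would repeat a 3.1-fold lower number from compound 1 to compound 2 (0.50 log units; beyond the scatter).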